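The source may hold more compounds than are shown below. What is called first, only, known or untested is meant among the compounds shown, and "the series" means these compounds.

Three compounds share one core and differ only in the group attached to the carbonyl carbon. Compound 1 `CC(C)(C(=O)O)C(c1ccc(Nc2ccc3ccccc3c2)cc1)n1ccnc1` carries a free acid, and in an assay on isolated protein for inhibition of cytochrome P450 26A1 (Homo sapiens), read by scintillation counting (a higher number here means a weaker inhibitor, a lower number a stronger inhibitor), compound 1 gives 300 nM. Compound 2 `CCCCOC(=O)C(C)(C)C(c1ccc(Nc2ccc3ccccc3c2)cc1)n1ccnc1` carries the butyl ester, and in this assay compound 2 gives 200 nM. Compound 3 `CC(C)(C(N)=O)C(c1ccc(Nc2ccc3ccccc3c2)cc1)n1ccnc1` carries the primary amide, and in this assay compound 3 gives 50 nM. Compound 3 stands lowest of the three: the two steps that reach it are a 4.0-fold lower number from compound 2 to compound 3 (0.60 log units; beyond the scatter) and a 6.0-fold lower number from compound 1 to compound 3 (0.78 log units; beyond the scatter), both beyond the scatter, so compound 3 is the strongest inhibitor of the measured set. Compound 4 `CC(C)NC(=O)C(C)(C)C(c1ccc(Nc2ccc3ccccc3c2)cc1)n1ccnc1` differs from compound 3 by isopropyl in place of hydrogen on an amide-type nitrogen. Among the measured compounds shown here, only one measured step resembles this one: in the acid-to-ester step a butyl chain was put on the oxygen next to the carbonyl, and that gave a 1.5-fold lower number from compound 1 to compound 2 (0.18 log units; within the scatter), within the scatter. An alkyl group on the heteroatom attached to the carbonyl thus changed little there, while swapping the heteroatom itself changed more. Compound 4 is therefore expected to land near compound 3, with the step expected to be a 1.6-fold higher number from compound 3 to compound 4 (0.20 log units; within the scatter). The estimate for compound 4 in this assay is 80 nM, expected between 30 nM and 250 nM.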

Compound 4, half-maximal inhibitory concentration: 120 nM
For compound 4 the middle estimate is 1.5-fold (0.18 log units) below the measured one; measured number inside the range.
By their numbers in this assay, from the lowest: compound 3; then compounds 4, 2 and 1 (each within the scatter of the next, the first and the last beyond it).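

In this assay, the amide-type nitrogen does not take an isopropyl group without a measurable change: there is a 2.4-fold higher number from compound 3 to compound 4 (0.38 log units; beyond the scatter), whereas the butyl group placed on the oxygen of the acid earlier stayed within the scatter. Having a nitrogen on the carbonyl carbon is therefore not enough on its own: compound 4 still shows a 2.5-fold lower number from compound 1 to compound 4 (0.40 log units; beyond the scatter), but a 1.7-fold lower number from compound 2 to compound 4 (0.22 log units; within the scatter) leaves it indistinguishable from the butyl ester, so among these compounds only the primary amide, compound 3, stands clear of all the others. No measurement available here explains why the isopropyl group has this effect.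

Going by these compounds, it remains open whether the change tracks the size of the group on the nitrogen, which a methyl or an ethyl group could test, alongside a longer chain or a cyclopropyl ring. A dimethylamide would also show what happens when both amide hydrogens are replaced, and a hydroxyethyl group would show whether a chain carrying a hydroxy group behaves like the isopropyl group.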